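Nitro to carbamate on the dimethylamino biphenyl

This account rests on a few compounds, and the source may have more. Where it says the series, first, only, none or still open, it means among the compounds named here.

Measured so far:
Compound 1 `CCOC(=O)c1cccc(-c2ccc(OCC)cc2)n1`: 79%
Compound 2 `CCOc1ccc(-c2cccc([N+](=O)[O-])c2)cc1`: 35%
Compound 3 `CN(C)c1ccc(-c2cccc([N+](=O)[O-])c2)cc1`: 21%

The account follows compound 3 to the unmeasured compound 4 `COC(=O)Nc1cccc(-c2ccc(N(C)C)cc2)c1`. In an assay on COS-7 cells for inhibition of patatin-like phospholipase domain-containing protein 2 (Mus musculus), tested at 200 uM (on this read-out higher numbers stand for more inhibition at the one concentration tested (going by the name of the read-out) and lower numbers for less inhibition), compound 3 gives 21%, the lowest of the three numbers; compound 2 gives 35%, and compound 1 gives 79%. For the measured compounds named here, the one step between measured compounds that differ in a single place is a number 14 percentage points lower from compound 2 to compound 3 (beyond the scatter), which concerns the group on the other ring and not the position changed here. The change from compound 3 to compound 4 is (methoxycarbonyl)amino in place of nitro on an aromatic carbon. Going by the values given here, no measured step bears on this change, so the estimate rests on compound 3 alone, and a step in this assay of no clear direction is expected, most likely within the scatter or only a little beyond it. Compound 4 is therefore expected to give 25%, with a range from 5% to 50%, which means an expected step of a number 4 percentage points higher from compound 3 to compound 4 (within the scatter).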

Compound 4, a percentage reported as inhibition, at one concentration (the size of the read-out at that concentration, not a potency): 95%
The estimate for compound 4 lay 70 percentage points below the measured number, and the stated range ends below it.
By their numbers in this assay, from the lowest: compound 3; then compound 2; then compound 1; then compound 4.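

For the compounds shown here, at this position the read-out proves far more responsive than the earlier compounds could suggest: in this assay, (methoxycarbonyl)amino in place of nitro gives a number 74 percentage points higher from compound 3 to compound 4 (beyond the scatter), well above the size of a number 14 percentage points lower from compound 2 to compound 3 (beyond the scatter) seen for dimethylamino in place of ethoxy on the other ring. The exchange keeps 2 hydrogen-bond acceptors and 1 double bond outside aromatic rings, while it goes from 0 hydrogen-bond donors to 1 hydrogen-bond donor and from 3 heavy atoms to 5 heavy atoms. No measurement shown explains the step or ties it to either of these differences.

The compounds shown leave open whether the whole carbamate matters, as a free amine or an acetamide at this place would separate the nitrogen from the methoxycarbonyl part. Also open, as far as these compounds go, is whether a longer chain, such as ethoxycarbonylamino, keeps the high number, and whether the same exchange does so with ethoxy on the other ring.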